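Methoxy in Place of Methyl: Compound 1 to Compound 4

This account rests on a few compounds, and the source may have more. Where it says the series, first, only, none or still open, it means among the compounds named here.

Compound 1 `Cc1cccc(NC(=O)N[C@H](C)c2ccccc2)c1` was tested in an ADME assay on the whole organism with Oryza sativa as the target, tested at 0.1 uM (on this read-out higher numbers stand for a weaker effect at the one concentration tested and lower numbers for a stronger effect), where compound 1 gives 100%. That is the largest of the three numbers on record, though it sits within the scatter of both others: compound 2 `Cc1cccc(NC(=O)N[C@@H](C)c2ccccc2)c1` gives 99% and compound 3 `C[C@@H](NC(=O)Nc1ccccc1C(F)(F)F)c1ccccc1` gives 99%. Going by the values given here, the only measured step, a number 1 percentage points lower from compound 1 to compound 2 (within the scatter), goes with the fact that compounds 1 and 2 differ only in the configuration as drawn and shows nothing beyond the scatter. Compound 4 `COc1cccc(NC(=O)N[C@H](C)c2ccccc2)c1` differs from compound 1 by methoxy in place of methyl on an aromatic carbon. Among the compounds with values here, no measured step exchanges a substituent of this kind, and all three numbers lie close together, so no step beyond the scatter is expected here. Compound 4 is therefore estimated at 98%, between 88% and 100%, which means an expected a number 2 percentage points lower from compound 1 to compound 4 (within the scatter).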

Compound 4, a percentage reported as activity, at one concentration (the size of the read-out at that concentration, not a potency): 104%
Beside the measured number, compound 4's estimate is 6 percentage points below it; the whole stated range lies below it.
By their numbers in this assay, from the lowest: compounds 2, 3, 1 and 4 (each within the scatter of the next).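

Going by these compounds alone, with methoxy in place of methyl on an aromatic carbon, meta to a large group, this assay gives a number 4 percentage points higher from compound 1 to compound 4 (within the scatter), the first exchange of a substituent at this position on record. Replacing methyl with methoxy adds a hydrogen-bond acceptor here and moves the read-out by no more than the scatter. No available evidence bears on this result. As far as these compounds go, whether an amine, a carboxylic acid or a longer chain on this aromatic carbon would give a step beyond the scatter remains open.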